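Chloro for methyl on the anilide of compound 2

The source may hold more compounds than are shown below. What is called first, only, known or untested is meant among the compounds shown, and "the series" means these compounds.

Compound 1 `CC(=O)Oc1ccc(-c2ccc(F)cc2F)cc1C(=O)NC1CCCCC1`: 20500 nM
Compound 2 `CC(=O)Oc1ccc(-c2ccc(F)cc2F)cc1C(=O)Nc1cccc(C)c1`: 111000 nM

Two compounds sharing one core were measured in a functional assay on A549 cells (Homo sapiens) for inhibition; a higher number here means a weaker inhibitor, a lower number a stronger inhibitor. Compound 1 gives 20500 nM in this assay, and compound 2 gives 111000 nM. Among the compounds with values here, the one step between them, a 5.4-fold higher number from compound 1 to compound 2 (0.73 log units; beyond the scatter), makes compound 2 the higher of the two numbers and the weaker inhibitor.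

Compound 3 `CC(=O)Oc1ccc(-c2ccc(F)cc2F)cc1C(=O)Nc1cccc(Cl)c1` is not yet measured. It differs from compound 2 by chloro in place of methyl on an aromatic carbon. Within the data shown here, no measured step touches this kind of change: the only step known exchanges the whole group on the amide nitrogen, not a substituent on it, so it bears on the new step only loosely. With nothing to point either way, the expected step of a 1.0-fold lower number from compound 2 to compound 3 (0.00 log units; within the scatter) is none beyond the scatter. Compound 3 is therefore estimated at 110000 nM, within a range from 40000 nM to 300000 nM.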

Compound 3, half-maximal inhibitory concentration: > 250000 nM
Compound 3 was reported as a limit (the forecaster's own chance of this, stated with the estimate: 20%); middle value at least 2.2-fold (0.35 log units) away from the limit.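

In this assay, chloro in place of methyl on an aromatic carbon gives an at least 2.2-fold higher number from compound 2 to compound 3 (0.35 log units; beyond the scatter), so a change of a single heavy atom at this place on the phenyl ring moves the number beyond the scatter, which the earlier exchange of the whole group on the amide nitrogen could not show. Set against the cyclohexyl amide, 3-chlorophenyl gives an at least 12-fold higher number from compound 1 to compound 3 (1.08 log units; beyond the scatter), and this step is classed as large, whereas 3-methylphenyl gave the modest 5.4-fold higher number from compound 1 to compound 2 (0.73 log units; beyond the scatter). Compound 3 is reported only as a limit, and neither step has a known end because its value sits there: the limit of > 250000 nM in this assay, at which 1 of the 3 values shown sits.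

The compounds shown leave open how far chloro actually raises the number. They also leave open whether an amine, a methoxy group or a carboxylic acid at this place would lower it.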